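The source may report more compounds than this note shows. Statements on the series, on what has been measured and on what is new or still open speak of the compounds shown alone.

Measured compounds:
Compound 1, `CCCNC(=O)C1CCN(C(=O)c2cc3sc(C(C)=O)cc3n2Cc2ccc(OC)cc2)CC1`: > 100000 nM
Compound 2, `CCCNC(=O)C1CCN(C(=O)c2cc3sc(CNCc4ccccc4)cc3n2Cc2ccc(OC)cc2)CC1`: 46800 nM

Both were tested in an ADME assay on HEK-293T cells (Homo sapiens) for cytotoxicity, read by luminescence, with a stated time of 24 h; on this read-out lower numbers stand for higher toxicity in this test and higher numbers for lower toxicity in this test. For compound 1 the entry > 100000 nM is a limit of this assay, not a number. Compound 2 gives 46800 nM, the only actual number shown. The measured step of an at least 2.1-fold lower number from compound 1 to compound 2 (0.32 log units; beyond the scatter) therefore rests on the limit of > 100000 nM in this assay, at which 1 of the 2 values shown sits, and gives only a floor for its size.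

Compound 3, `CCCNC(=O)C1CCN(C(=O)c2cc3sc(-c4ccccc4)cc3n2Cc2ccc(OC)cc2)CC1`, differs from compound 2 by phenyl in place of (benzylamino)methyl on an aromatic carbon. Going by the values given here, the one measured step touched the same position but swapped different groups, so it bears on this change only loosely. With the chain and its amine removed and a plain aromatic ring put in, the expected step of a 1.7-fold higher number from compound 2 to compound 3 (0.23 log units; within the scatter) is estimated to run toward lower toxicity, though with wide uncertainty. Compound 3 is expected to give about 80000 nM, within 30000 nM to 200000 nM.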

Compound 3, half-maximal cytotoxic concentration: > 100000 nM
Compound 3 was reported as a limit (the forecaster's own chance of this, stated with the estimate: 40%); middle value at least 1.2-fold (0.09 log units) from the limit.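

In this assay, compound 3 gives > 100000 nM, which is a limit of the assay and not a number. Putting phenyl in place of (benzylamino)methyl on this aromatic carbon, next to the ring sulfur, gives an at least 2.1-fold higher number from compound 2 to compound 3 (0.32 log units; beyond the scatter), so a six-membered aromatic ring at this carbon does not by itself bring the number down, since the group that leaves and the group that enters each contain one. The step from compound 1 to compound 3 cannot be read, and the size of the step to compound 3 is only a floor: the limit of > 100000 nM in this assay, at which 2 of the 3 values shown sit.

It stays open whether the nitrogen of the (benzylamino)methyl group or the length of its chain accounts for the lower number, as no compound shown carries a plain aminomethyl group or an all-carbon chain ending in phenyl. On these data alone, how a carboxylic acid at this carbon would read in this assay also stays open.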